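The compounds below may be only part of what the source reports. "The series", "measured", "known", "first", "only" and "open" are said of these compounds alone.

For the measured compounds named here, compound 1, whose structure is `CC1(Cc2ccc(/C(N)=N/O)cc2)CC(S(=O)(=O)c2ccc(F)cc2)=C(c2ccc(/C(N)=N/O)cc2)O1`, is the one with the lowest number among the two values given in an ADME assay on cells (Peritoneal macrophage, Mus musculus, strain Balb/c) for cytotoxicity, read by resazurin assay, with a stated time of 72 h (on this read-out higher numbers stand for lower toxicity in this test and lower numbers for higher toxicity in this test), where compound 1 gives 42200 nM. Compound 2, `CC1(Cc2ccccc2C(F)(F)F)CC(S(=O)(=O)c2ccc(F)cc2)=C(c2ccc(/C(N)=N/O)cc2)O1`, gives 105000 nM in this assay. Compound 3, `CC1(Cc2ccc(CO)cc2)CC(S(=O)(=O)c2ccc(F)cc2)=C(c2ccc(/C(N)=N/O)cc2)O1`, reaches only a limit of this assay, > 100000 nM, so the limit of > 100000 nM in this assay, at which 1 of the 3 values shown sits, is all that is known of it. The step to compound 2 was a 2.5-fold higher number from compound 1 to compound 2 (0.40 log units; beyond the scatter) and the step to compound 3 was an at least 2.3-fold higher number from compound 1 to compound 3 (0.37 log units; beyond the scatter). Compound 4, `CC1(Cc2cccc(CO)c2)CC(S(=O)(=O)c2ccc(F)cc2)=C(c2ccc(/C(N)=N/O)cc2)O1`, differs from compound 1 in that (a group of 8 heavy atoms (7 carbon, 1 oxygen; one six-membered aromatic ring of carbon only) in place of a group of 10 heavy atoms (7 carbon, 2 nitrogen, 1 oxygen; one six-membered aromatic ring of carbon only), on a saturated chain carbon bound to a saturated ring carbon). Both measured steps that replace the same group read upward, and compound 3, which also carries a hydroxymethyl-bearing ring in that place, sits at the limit. Compound 4 is therefore expected to show a 2.4-fold higher number from compound 1 to compound 4 (0.37 log units; beyond the scatter), with a fair chance that this assay again reports only a limit. The estimate for compound 4 is 100000 nM, from 45000 nM to 220000 nM.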

Compound 4, half-maximal cytotoxic concentration: > 100000 nM
Compound 4 gave a limit, no number (the forecaster's own chance of this, stated with the estimate: 55%); the middle value sits exactly at the limit.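

At this saturated chain carbon bound to a saturated ring carbon, 3-(hydroxymethyl)phenyl now also moves the read-out of this assay upward, giving an at least 2.3-fold higher number from compound 1 to compound 4 (0.37 log units; beyond the scatter). Compound 4 yields no number but only a limit of the assay, and with it a second hydroxymethyl-bearing ring stands at that limit: the limit of > 100000 nM in this assay, at which 2 of the 4 values shown sit. The steps from compound 3 to compound 4 and from compound 2 to compound 4 cannot be read, and any difference between 3-(hydroxymethyl)phenyl and 4-(hydroxymethyl)phenyl at this place remains hidden.

The compounds shown leave open how far compound 3 and compound 4 would lie past the limit. They also leave open whether an amine or a carboxylic acid in place of the hydroxymethyl on this ring would read the same in this assay.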